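Cyclohexyl in Place of sec-Butyl: Three Compounds, One Forecast

The source may report more compounds than this note shows. Statements on the series, on what has been measured and on what is new or still open speak of the compounds shown alone.

Three compounds have been measured in a functional assay on Caco-2 cells (Homo sapiens) for inhibition, read by sulforhodamine B assay, with a stated time of 72 h; a higher number here means a weaker inhibitor, a lower number a stronger inhibitor:
compound 1 `COc1cc(/C=C/C(=O)/C=C(/C=C/c2ccc(OC(C)=O)c(OC)c2)NC2CCCCC2)ccc1OC(C)=O` gives 4400 nM;
compound 2 `CCC(C)NC(=C\C(=O)/C=C/c1ccc(O)cc1)/C=C/c1ccc(O)cc1` gives 5800 nM;
compound 3 `CCC(C)NC(=C\C(=O)/C=C/c1ccc(OC(C)=O)c(OC)c1)/C=C/c1ccc(OC(C)=O)c(OC)c1` gives 24000 nM.

Compound 3 and compound 1 share a core and differ in a single place: cyclohexyl in place of sec-butyl on an amine nitrogen. This change produced a 5.5-fold lower number from compound 3 to compound 1 (0.74 log units; beyond the scatter), so the cyclohexyl compound is the stronger inhibitor of the pair. Compound 2 carries a different core from compound 3; the difference between the two cores is not broken down here. Compound 2 and compound 1 give numbers within the scatter of each other, so nothing can be said about their order.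

Compound 4 `O=C(/C=C(/C=C/c1ccc(O)cc1)NC1CCCCC1)/C=C/c1ccc(O)cc1` has not yet been measured. It stands to compound 2 as compound 1 stands to compound 3: cyclohexyl in place of sec-butyl on an amine nitrogen. The place of the change reads the same in both pairs, so this is the same change, applied now to the core of compound 2 rather than the core of compound 3.

Within the data shown here, only one measured example of this change exists, and it sits on the other core, so the forecast is uncertain. Still, the expected step from compound 2 to compound 4 is a 3.9-fold lower number from compound 2 to compound 4 (0.59 log units; beyond the scatter), kept a little smaller than the measured one because a 5.5-fold lower number from compound 3 to compound 1 (0.74 log units; beyond the scatter) is a single step on the other core and may not carry fully onto a second core. Compound 4 is therefore estimated at 1500 nM in this assay. The estimated range for compound 4 is expected to run from 600 nM to 4500 nM.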

Compound 4, half-maximal inhibitory concentration: 6900 nM
For compound 4 the middle estimate is 4.6-fold (0.66 log units) below the measured one; the whole stated range lies below it.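

In this assay, putting cyclohexyl in place of sec-butyl on the amine nitrogen gives a 1.2-fold higher number from compound 2 to compound 4 (0.08 log units; within the scatter), so on this core the two compounds cannot be told apart. The change therefore does not act alike on the two cores, and the difference between its two outcomes is larger than chance scatter would readily explain: the same change on two cores in this assay, a 5.5-fold lower number (0.74 log units; beyond the scatter) from compound 3 to compound 1 and a 1.2-fold higher number (0.08 log units; within the scatter) from compound 2 to compound 4, 6.5-fold (0.81 log units) apart, beyond the scatter of two such steps. This shows that a step measured on one core of this series cannot simply be added to a compound with another core, but it does not show which feature of the cores makes the difference, nor why the cyclohexyl group counts on one core and not on the other, as two pairs give only a comparison and no explanation.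

The compounds shown leave open whether the split between the cores is particular to cyclohexyl and sec-butyl, or whether other groups on the same nitrogen, such as a straight butyl chain, a benzyl group or a cyclopentyl ring, would also behave differently on the two cores. They also leave open which part of the difference between the cores matters, since no compound shown carries only part of that difference.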